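Phenyl for tert-butyl on the side-chain amine

The source may hold more compounds than are shown below. What is called first, only, known or untested is meant among the compounds shown, and "the series" means these compounds.

In a functional assay on MCF7 cells (Homo sapiens) for antiproliferative activity (on this read-out lower numbers stand for stronger inhibition and higher numbers for weaker inhibition), compound 1 `CC(C)=CCc1cc(C(=O)Nc2cc3ccc(OCCCN(C)C(C)C)c(C)c3oc2=O)ccc1O` gives 1050 nM and compound 2 `CC(C)=CCc1cc(C(=O)Nc2cc3ccc(OCCCNC(C)(C)C)c(C)c3oc2=O)ccc1O` gives 950 nM, so compound 2 stands level with compound 1 within the scatter. Compound 3 `CC(C)=CCc1cc(C(=O)Nc2cc3ccc(OCCCNc4ccccc4)c(C)c3oc2=O)ccc1O` carries phenyl in place of tert-butyl on an amine nitrogen. For the measured compounds named here, the only measured step, a 1.1-fold lower number from compound 1 to compound 2 (0.04 log units; within the scatter), lay within the scatter, but it brought in no ring, so it offers only a weak guide here. The expected change is small, not clearly beyond the scatter, at a 1.3-fold higher number from compound 2 to compound 3 (0.10 log units; within the scatter). In this assay, compound 3 is estimated at 1200 nM, with an expected range of 400 nM to 3500 nM.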

Compound 3, half-maximal inhibitory concentration: > 50000 nM
Compound 3: only a limit was reported (the forecaster's own chance of this, stated with the estimate: 10%); at least 41-fold (1.61 log units) between middle value and limit.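

The amine on the side chain is not indifferent to what it carries: with an at least 52-fold higher number from compound 2 to compound 3 (1.72 log units; beyond the scatter) for phenyl in place of tert-butyl, and an at least 47-fold higher number from compound 1 to compound 3 (1.67 log units; beyond the scatter) for anilino in place of isopropyl(methyl)amino, activity in this assay falls away, a loss that the level pair of compound 1 and compound 2 gave no sign of. The value of compound 3 is a limit and not a number, so these steps give only a floor: the limit of > 50000 nM in this assay, at which 1 of the 3 values shown sits.

Still open, as far as these compounds go, is whether the loss follows the aromatic ring itself or its direct attachment to the nitrogen. A benzyl or a cyclohexyl group on the amine would help separate the two.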